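Aryl sulfonamide series: bromo to phenyl and metabolic stability

A few compounds are considered here, and "the series" means these few. Any claim that something is new, unique, unknown or untested is made for them only; others in the source may bear on it.

Measured in an ADME assay on S9 fraction from liver (Mus musculus, strain ICR/CD-1) for metabolic stability, read by LC-MS, using NADPH, with a stated time of 5 min, tested at 2 uM; a higher number here means that the compound lasts longer, a lower number that the compound disappears faster:
Compound 1 `CC1CCN(C2CCN(S(=O)(=O)c3ccccc3Br)CC2)CC1`: 0.1 h
Compound 3 `CC1CCN(C2CCN(S(=O)(=O)c3cccc(Br)c3)CC2)CC1`: 0.217 h
Compound 2 `CC1CCN(C2CCN(S(=O)(=O)c3ccccc3-c3ccccc3)CC2)CC1` gives only an assay limit, < 0.1 h.

Moving the bromo, (3-bromophenyl in place of 2-bromophenyl on a sulfonyl sulfur), gives a 2.2-fold higher number from compound 1 to compound 3 (0.34 log units; beyond the scatter); compound 3 has the highest number of the two numbers read. Replacing bromo by phenyl on the core of compound 1, (phenyl in place of bromo on an aromatic carbon), gives a number no higher from compound 1 to compound 2 (the limit leaves the size open); the size of that step is not readable because of the limit of < 0.1 h in this assay, at which 1 of the 3 values shown sits.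

Compound 4 `CC1CCN(C2CCN(S(=O)(=O)c3cccc(-c4ccccc4)c3)CC2)CC1` carries the same kind of change on the core of compound 3, (phenyl in place of bromo on an aromatic carbon). The place differs from the earlier pair: there the phenyl enters ortho to a large group, here meta to a large group.

Expectation: the earlier step gives only a direction, no size, and the gap between compound 3 and compound 1 is taken as a guide for the size. The step of a 1.8-fold lower number from compound 3 to compound 4 (0.26 log units; within the scatter) is estimated as a drop of roughly that order. Compound 4 is therefore expected near 0.12 h, between 0.05 h and 0.25 h.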

Compound 4, half-life: 0.517 h
Estimate against measurement, compound 4: 4.3-fold (0.63 log units) below; measured number above the stated range.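

In this assay, phenyl in place of bromo on an aromatic carbon, meta to a large group, gives a 2.4-fold higher number from compound 3 to compound 4 (0.38 log units; beyond the scatter). Compound 2 gives only an assay limit, < 0.1 h, and the size of the step to it cannot be read. The result shows that this change can raise the half-life on the core of compound 3, but it does not show that a size or a direction of change carries from one core to the other: the same change on two cores in this assay, a number no higher (the limit leaves the size open) from compound 1 to compound 2 and a 2.4-fold higher number (0.38 log units; beyond the scatter) from compound 3 to compound 4; the limit leaves it open whether they differ.

From the compounds shown here alone, it remains open whether the higher number on the core of compound 3 is specific to phenyl or would also appear with another group in the same place, such as methoxy, a nitrile, an amine, a carboxylic acid or a longer chain. Also open is whether the same step would hold on cores that differ from these two elsewhere in the structure, as all the compounds shown keep the rest of the shared core unchanged.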